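The source may report more compounds than this note shows. Statements on the series, on what has been measured and on what is new or still open speak of the compounds shown alone.

Among the compounds with values here, compound 2, with the structure `Cc1cccc(-n2nc(-c3ccccc3)nc2CNc2ccc(C(=O)NO)cc2)c1`, gives the largest number of the three compounds measured so far in an assay on Sf9 cells for inhibition of protein deacetylase HDAC6 (Homo sapiens), read by fluorescence, with a stated time of 40 min, tested at 100 nM (a higher number here means more inhibition at the concentration tested (going by the name of the read-out), a lower number less inhibition), namely 66%. Compound 1, `Cc1ccccc1-n1nc(-c2ccccc2)nc1CNc1ccc(C(=O)NO)cc1`, gives 57.1% in this assay, and the step of a number 8.9 percentage points higher from compound 1 to compound 2 (within the scatter) is within the scatter, so the two cannot be ranked against each other. Within the data shown here, compound 3, `O=C(O)c1ccc(NCc2nc(-c3ccccc3)nn2-c2ccccc2)cc1`, which carries a carboxylic acid where the other two carry a hydroxamic acid, gives -0.4%; no single-change step to compound 2 is available, and the two values simply show a wide gap.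

Compound 4, `CCc1ccc(-n2nc(-c3ccccc3)nc2CNc2ccc(C(=O)NO)cc2)cc1`, has not yet been measured. It differs from compound 2 in one place: 4-ethylphenyl in place of 3-methylphenyl on an aromatic nitrogen. Among the measured compounds shown here, the only measured step that touches the same position is the one from compound 1 to compound 2, where the pattern on that phenyl changed and the number moved by a number 8.9 percentage points higher from compound 1 to compound 2 (within the scatter), within the scatter. Nothing in the measured set speaks to an ethyl group on this ring, so there is no basis to expect a move beyond the scatter in either direction. The step of a number 4 percentage points lower from compound 2 to compound 4 (within the scatter) is therefore expected to be small. Compound 4 is estimated to give 62% in this assay, with a range from 38% to 80%.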

Compound 4, a percentage reported as inhibition, at one concentration (the size of the read-out at that concentration, not a potency): 38.3%
Estimate against measurement, compound 4: 23.7 percentage points above; the range from low to high includes it.
By their numbers in this assay, from the lowest: compound 3; then compound 4; then compounds 1 and 2 (each within the scatter of the next).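

Within the data shown here, the group on the aromatic nitrogen turns out not to be indifferent in this assay: the change to 4-ethylphenyl gives a number 27.7 percentage points lower from compound 2 to compound 4 (beyond the scatter), and likewise a number 18.8 percentage points lower from compound 1 to compound 4 (beyond the scatter), whereas the only earlier step at this place, between the two methylphenyl groups, stayed within the scatter. So this place on the shared core can shift the read-out by more than the scatter, and both methylphenyl compounds stand apart from the 4-ethylphenyl compound, although they cannot be ranked against each other. Each of the two steps changes the alkyl group and its place on the phenyl ring together, so the effect of the ethyl group cannot be separated from that of its location, and nothing measured independently bears on the loss seen with compound 4.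

A 4-methylphenyl or a 3-ethylphenyl group on the same nitrogen would pull these two changes apart, and the compounds shown leave open how either would read. They also leave open how an unsubstituted phenyl, a longer chain such as propyl, or an amine on this ring would compare.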